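A few compounds are considered here, and "the series" means these few. Any claim that something is new, unique, unknown or untested is made for them only; others in the source may bear on it.

Of the compounds shown here, two of a shared core have been measured in an assay for inhibition of Polyunsaturated fatty acid 5-lipoxygenase (Homo sapiens), tested at 1 uM; a higher number here means a weaker effect of the compound at the concentration tested, a lower number a stronger effect. Compound 1 `CCOC(=O)CSc1nc(Cl)cc(Nc2cccc(C)c2C)n1` gives 76.9% in this assay. For the measured compounds named here, compound 2 `CCOC(=O)CSc1nc(Cl)cc(Nc2ccc3ncccc3c2)n1` gives 86.3% in this assay, the highest of the two numbers so far, though its nearest neighbour, compound 1, lies within the usual scatter of it, so the two values cannot be ordered. Both numbers show weak inhibition at the concentration tested.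

Compound 3 `CCCCC(Sc1nc(Cl)cc(Nc2ccc3ncccc3c2)n1)C(=O)OCC` has not yet been measured. It differs from compound 2 in one place: butyl in place of hydrogen on a saturated chain carbon bound to a carbonyl carbon and a sulfur. Going by the values given here, no step between two measured compounds resembles this change, so the data give no guide to its size or direction. In this assay compound 3 is expected to sit close to compound 2, with a step of a number 4.3 percentage points lower from compound 2 to compound 3 (within the scatter) that is not expected to exceed the scatter in either direction. Compound 3 is therefore estimated at 82% in this assay, with a range from 62% to 100%, the measurement to be reported later.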

Compound 3, a percentage reported as activity, at one concentration (the size of the read-out at that concentration, not a potency): 51.8%
Estimate against measurement, compound 3: 30.2 percentage points above, and the stated range ends above it.
By their numbers in this assay, from the lowest: compound 3; then compounds 1 and 2 (each within the scatter of the next).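

The saturated chain carbon bound to a carbonyl carbon and a sulfur proves to be a place where substitution matters in this assay: butyl in place of hydrogen there gives a step of a number 34.5 percentage points lower from compound 2 to compound 3 (beyond the scatter). For the compounds shown here, compound 1 and compound 2 carry the same unsubstituted chain at this carbon and could say nothing about it, so this is the first sign that the effect at the concentration tested responds to a change here, and that a group with no ring, no hydrogen-bond donors and no hydrogen-bond acceptors is enough to produce it. Nothing available bears on why the number falls with this change.

The compounds shown leave open whether this step belongs to butyl itself or would also come with a shorter chain such as methyl, a longer chain such as hexyl, or a ring such as phenyl at the same carbon. They also leave open whether butyl would give a step of like size on the core of compound 1, and whether a carboxylic acid in place of the ethyl ester would hold the number of compound 3, 51.8%.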